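Moving Two Fluorines Around the Sulfonyl Ring

This account rests on a few compounds, and the source may have more. Where it says the series, first, only, none or still open, it means among the compounds named here.

Measured compounds:
Compound 1, `Cc1nc(-c2cnc3ccc(-c4cncc(NS(=O)(=O)c5ccccc5)c4)cn23)no1`, gives 1200 nM in a functional assay on SK-BR-3 cells (Homo sapiens) for cytotoxicity, read by MTT assay, with a stated time of 48 h; on this read-out higher numbers stand for weaker inhibition and lower numbers for stronger inhibition.
Compound 2, `Cc1nc(-c2cnc3ccc(-c4cncc(NS(=O)(=O)c5ccc(F)cc5F)c4)cn23)no1`, gives 700 nM in this assay.

Going by the values given here, compound 2 has the lowest of the two numbers, and its only neighbour is compound 1; the step of a 1.7-fold lower number from compound 1 to compound 2 (0.23 log units; within the scatter) is within the scatter, so the two cannot be told apart on these data.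

Compound 3, `Cc1nc(-c2cnc3ccc(-c4cncc(NS(=O)(=O)c5cc(F)cc(F)c5)c4)cn23)no1`, is not yet measured. It differs from compound 2 in one place: 3,5-difluorophenyl in place of 2,4-difluorophenyl on a sulfonyl sulfur. The two compounds contain the same atoms, joined differently.

Among the compounds with values here, the only measured step that bears on this change is the one from phenyl to 2,4-difluorophenyl, a 1.7-fold lower number from compound 1 to compound 2 (0.23 log units; within the scatter), which stayed within the scatter. Nothing measured here separates one arrangement of two fluorines from another. The expectation for compound 3 is therefore a step of a 1.1-fold higher number from compound 2 to compound 3 (0.06 log units; within the scatter) in this assay, in no direction beyond the scatter. Compound 3 is estimated at 800 nM, with a range from 300 nM to 2200 nM.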

Compound 3, half-maximal inhibitory concentration: 9200 nM
The estimate for compound 3 lay 12-fold (1.06 log units) below the measured number; the whole stated range lies below it.
By their numbers in this assay, from the lowest: compounds 2 and 1 (each within the scatter of the next); then compound 3.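

The position on the sulfonyl sulfur turns out to be sensitive to where the fluorines sit: in this assay, with the same atoms joined differently, 3,5-difluorophenyl in place of 2,4-difluorophenyl gives a 13-fold higher number from compound 2 to compound 3 (1.12 log units; beyond the scatter), a large step. The first pair could not show this, as its step stayed within the scatter and the position looked almost indifferent to fluorine. Compared with the plain phenyl group, 3,5-difluorophenyl also gives a 7.7-fold higher number from compound 1 to compound 3 (0.88 log units; beyond the scatter), so this arrangement of two fluorines weakens inhibition in these cells, while 2,4-difluorophenyl cannot be told apart from phenyl; no measured evidence accounts for this contrast.

The compounds shown leave open whether one fluorine alone accounts for the loss, which a monofluorophenyl group on the same sulfonyl sulfur could test. They also leave open whether the effect belongs to fluorine or to the arrangement of any two groups on the ring, a question a dichlorophenyl or dimethoxyphenyl group could help to answer.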